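The source may hold more compounds than are shown below. What is called first, only, known or untested is meant among the compounds shown, and "the series" means these compounds.

Compound 3 `COc1ccc2[nH]c(C(=O)N3CC(=O)N(Cc4ccccc4)[C@@H](CN4CCc5ccccc5C4)C3)cc2c1` gives 0.617 h in an ADME assay on microsomes from liver (Homo sapiens) for metabolic stability, with a stated time of 30 min, tested at 1 uM; a higher number here means that the compound lasts longer, a lower number that the compound disappears faster. Compound 1 `COc1ccc2[nH]c(C(=O)N3CC(=O)N(Cc4ccccc4)[C@@H](COc4ccc(F)cc4)C3)cc2c1` gives 0.317 h in this assay, and compound 2 `COc1ccc2[nH]c(C(=O)N3CC(=O)N(Cc4ccccc4)[C@@H](CN4CCC(C(C)C)CC4)C3)cc2c1` gives 0.317 h. Compound 3 holds the largest of the three numbers, but the steps of a 1.9-fold higher number from compound 1 to compound 3 (0.29 log units; within the scatter) and a 1.9-fold higher number from compound 2 to compound 3 (0.29 log units; within the scatter) both lie within the scatter, as does no change at the digits printed from compound 1 to compound 2 (within the scatter), so no ordering among the three compounds is established on these data.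

Compound 4 `COc1ccc2[nH]c(C(=O)N3CC(=O)N(Cc4ccccc4)[C@@H](CN4CCCc5ccccc54)C3)cc2c1` has not yet been measured in this assay. It differs from compound 3 by 1,2,3,4-tetrahydroquinolin-1-yl in place of 1,2,3,4-tetrahydroisoquinolin-2-yl on a saturated chain carbon bound to a saturated ring carbon. The measured steps that bear on this change are the ones at the same position: a 1.9-fold higher number from compound 1 to compound 3 (0.29 log units; within the scatter), a 1.9-fold higher number from compound 2 to compound 3 (0.29 log units; within the scatter) and no change at the digits printed from compound 1 to compound 2 (within the scatter). Each of these exchanges on the saturated chain carbon bound to a saturated ring carbon left the number within the scatter, whether the entering group was 4-isopropylpiperidin-1-yl or 1,2,3,4-tetrahydroisoquinolin-2-yl. No exchange at this position has so far moved this assay beyond the scatter, and the change to compound 4 keeps the same atoms, joined differently. The step of a 1.2-fold lower number from compound 3 to compound 4 (0.09 log units; within the scatter) is therefore expected to stay within the scatter, with no direction to be assigned. For compound 4 the estimate in this assay is 0.5 h, with a range from 0.25 h to 1 h.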

Compound 4, half-life: 0.183 h
For compound 4 the middle estimate is 2.7-fold (0.44 log units) above the measured one; the whole stated range lies above it.
By their numbers in this assay, from the lowest: compounds 4, 1, 2 and 3 (each within the scatter of the next, the first and the last beyond it).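

In this assay, within the data shown here, the exchange on the saturated chain carbon bound to a saturated ring carbon now gives a 3.4-fold lower number from compound 3 to compound 4 (0.53 log units; beyond the scatter) as the first step at this position to lie beyond the scatter, and it arises with 1,2,3,4-tetrahydroquinolin-1-yl in place of 1,2,3,4-tetrahydroisoquinolin-2-yl, two groups with the same atoms joined differently. The position therefore responds to how these atoms are joined, even though the steps of a 1.7-fold lower number from compound 2 to compound 4 (0.24 log units; within the scatter) and a 1.7-fold lower number from compound 1 to compound 4 (0.24 log units; within the scatter) stay within the scatter and only compound 3 and compound 4 are separated from each other. No measurement is available that would account for the difference between these two groups.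

From the compounds shown here alone, whether a morpholine ring, a dimethylamino group or a carboxylic acid on the same saturated chain carbon would stay within the scatter of compound 3 or of compound 4 remains open. Also open, going by these compounds, is whether the same exchange of 1,2,3,4-tetrahydroisoquinolin-2-yl for 1,2,3,4-tetrahydroquinolin-1-yl would give a step of similar size on a different core, since a single pair carries this finding.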